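A Carboxyphenyl Swap at the Cytotoxicity Ceiling

The source may hold more compounds than are shown below. What is called first, only, known or untested is meant among the compounds shown, and "the series" means these compounds.

Compound 1 `N#CCCCn1c(Cn2c(=O)n(-c3ccncc3F)c3ccncc32)cc2cc(Cl)ccc21`: > 50000 nM
Compound 2 `O=c1n(Cc2nc3cnccc3n2CCCCO)c2cnccc2n1C1CC1`: > 100000 nM
Compound 3 `O=c1n(Cc2cc3ccc(Cl)cc3n2CCCCO)c2cnccc2n1C1CC1`: > 50000 nM

In an ADME assay on HeLa cells (Homo sapiens) for cytotoxicity, read by ATP content, with a stated time of 3 days (a higher number here means that more compound is tolerated, a lower number that less compound is tolerated), compound 1 gives > 50000 nM, which is a limit of the assay and not a measured number. Compound 2 gives > 100000 nM, likewise a limit. Compound 3 gives > 50000 nM, again a limit. None of the three compounds therefore shows measurable harm to the cells within the range tested. Compound 1 sits at the limit of > 50000 nM in this assay, at which 2 of the 3 values shown sit, together with compound 3, whereas compound 2 reaches (the limit of > 100000 nM in this assay, at which 1 of the 3 values shown sits). No two of these compounds differ in a single place, so no measured step is available to calibrate the change that follows.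

Compound 4 `N#CCCCn1c(Cn2c(=O)n(-c3ccc(C(=O)O)cc3)c3ccncc32)cc2cc(Cl)ccc21` differs from compound 1 by 4-carboxyphenyl in place of 3-fluoropyridin-4-yl on an aromatic nitrogen. With all three measured compounds at a limit, the step is expected to be none beyond the scatter, so that a step that the limit leaves unreadable from compound 1 to compound 4 is expected to be essentially flat. Compound 4 is expected to give 60000 nM in this assay, within a range from 20000 nM to 150000 nM, most probably reported once more as a limit.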

Compound 4, half-maximal cytotoxic concentration: > 50000 nM
Compound 4: no number, only a limit; the forecaster's own chance of this, stated with the estimate: 85%; the middle value is on the limit's open side.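

Among these compounds, compound 1 and compound 4 both give only a limit in this assay, and no step from one to the other can be read. The compounds shown leave open what concentration of either compound harms the cells, and whether 4-carboxyphenyl in place of 3-fluoropyridin-4-yl changes it.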